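The source may hold more compounds than are shown below. What is called first, only, known or untested is meant among the compounds shown, and "the series" means these compounds.

Measured so far:
compound 1, `Cc1cc(C)n(-c2nc(-c3ccc(F)cc3)cc(=O)[nH]2)n1`: 4000 nM
compound 2, `Cc1cc(-c2ccccc2)n(-c2nc(C(F)(F)F)cc(=O)[nH]2)n1`: > 50000 nM

In an ADME assay on CHO cells (Cricetulus griseus) for cytotoxicity, read by MTT assay (a lower number here means a stronger inhibitor, a higher number a weaker inhibitor), compound 1 gives 4000 nM. For compound 2 the result is only a limit, not a number: compound 2 gives > 50000 nM, which is the limit of > 50000 nM in this assay, at which 1 of the 2 values shown sits. Compound 2 thus stands at the weak end of what has been measured. Compound 3, `Cc1cc(Nc2ccccn2)n(-c2nc(C(F)(F)F)cc(=O)[nH]2)n1`, has not been measured. It differs from compound 2 in one place: (pyridin-2-yl)amino in place of phenyl on an aromatic carbon. Among the measured compounds shown here, no step between measured compounds is available to say how such a change plays out in this assay. The step of a number no higher from compound 2 to compound 3 (the limit leaves the size open) is expected to be none beyond the scatter. Compound 3 is expected to remain near the limit, with the result in this assay most likely again reported as a limit rather than a number. Compound 3 is therefore estimated at 50000 nM, within a range from 20000 nM to 150000 nM.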

Compound 3, half-maximal inhibitory concentration: 23000 nM
Beside the measured number, compound 3's estimate is 2.2-fold (0.34 log units) above it; the measured number falls inside the stated range.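

In this assay, this aromatic carbon, next to the ring nitrogen of the five-membered ring, proves responsive to the group it carries: (pyridin-2-yl)amino in place of phenyl gives an at least 2.1-fold lower number from compound 2 to compound 3 (0.33 log units; beyond the scatter), and compound 3 yields a number where compound 2 did not. On these data alone, that step lies beyond the scatter, but how far beyond stays unknown, since the value of compound 2 is a limit and not a number: the limit of > 50000 nM in this assay, at which 1 of the 3 values shown sits. Compound 1 differs from both in more than one place, so it says nothing about this change.

As far as these compounds go, whether a plain amine or a phenylamino group on this carbon would give a number like that of compound 3 remains open. So does whether the same change would act alike on the core of compound 1.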